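A Smaller Saturated Amine at the Aromatic Carbon

The source may hold more compounds than are shown below. What is called first, only, known or untested is meant among the compounds shown, and "the series" means these compounds.

Of the compounds shown here, three sharing one core have been measured in a functional assay on CHO-K1 cells for antagonist activity at transient receptor potential cation channel subfamily V member 1 (Homo sapiens), read by FLIPR; a lower number here means a stronger inhibitor, a higher number a weaker inhibitor. Compound 1 `Cc1ccc(Cl)cc1Nc1nc(C(F)(F)F)ccc1CNC(=O)C(C)c1ccc(NS(C)(=O)=O)c(F)c1` gives 140 nM. Compound 2 `CCCN(CCC)c1nc(C(F)(F)F)ccc1CNC(=O)C(C)c1ccc(NS(C)(=O)=O)c(F)c1` gives 14.7 nM, and compound 3 `CC(C(=O)NCc1ccc(C(F)(F)F)nc1N1CCC(c2ccccc2)CC1)c1ccc(NS(C)(=O)=O)c(F)c1` gives 25 nM. Among these three numbers compound 3 stands second highest; it is close to compound 2 and well separated from compound 1. The two measured steps that lead to it are sizeable: a 9.5-fold lower number from compound 1 to compound 2 (0.98 log units; beyond the scatter) and a 5.6-fold lower number from compound 1 to compound 3 (0.75 log units; beyond the scatter). By contrast, a 1.7-fold higher number from compound 2 to compound 3 (0.23 log units; within the scatter), so exchanging one saturated amine for another at this position left the number essentially where it was.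

Compound 4 `CC(C(=O)NCc1ccc(C(F)(F)F)nc1N1CCCCCC1)c1ccc(NS(C)(=O)=O)c(F)c1` differs from compound 3 in one place: azepan-1-yl in place of 4-phenylpiperidin-1-yl on an aromatic carbon. This most resembles the move between compound 2 and compound 3, a pair of saturated amines whose numbers sit within the scatter of each other. Within the data shown here, no measured step covers azepan-1-yl itself. On this basis the expected step is a 1.3-fold lower number from compound 3 to compound 4 (0.10 log units; within the scatter), that is, nothing beyond the scatter. Compound 4 is therefore estimated at 20 nM, with a range from 8 nM to 50 nM.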

Compound 4, half-maximal inhibitory concentration: 25.1 nM
Compound 4: the middle estimate sits 1.3-fold (0.10 log units) below what was measured; the measured number falls inside the stated range.
By their numbers in this assay, from the lowest: compounds 2, 3 and 4 (each within the scatter of the next); then compound 1.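

Replacing 4-phenylpiperidin-1-yl with the smaller azepan-1-yl gives a 1.0-fold higher number from compound 3 to compound 4 (0.00 log units; within the scatter) in this assay, so at this position the number holds even without the six-membered aromatic ring of carbon only. The seven-membered ring also compares with the open-chain dipropylamino group as a 1.7-fold higher number from compound 2 to compound 4 (0.23 log units; within the scatter) and so a single ring and two separate chains on this carbon cannot be told apart by this measurement. Against the (5-chloro-2-methylphenyl)amino group of compound 1 the result is a 5.6-fold lower number from compound 1 to compound 4 (0.75 log units; beyond the scatter) and compound 4 thereby joins compound 2 and compound 3 as a third saturated amine with a lower number, with no shown compound going against that pattern.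

Still open, going by these compounds, is whether a smaller ring such as pyrrolidine, or a ring with an added oxygen such as morpholine, would keep the number in the same place. Nothing available here explains why these three amines give such similar numbers.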